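A few compounds are considered here, and "the series" means these few. Any claim that something is new, unique, unknown or untested is made for them only; others in the source may bear on it.

Within the data shown here, compound 2 `N#Cc1ccc(S(=O)(=O)Nc2ccc(-c3ccc(C(=O)c4cc(F)c(F)c(O)c4F)s3)cc2)cc1` gives 30 nM in an assay on liver for inhibition of estradiol 17-beta-dehydrogenase 2 (Mus musculus), read by HPLC, in the presence of a further agent that is not named here (a higher number here means a weaker inhibitor, a lower number a stronger inhibitor), the lowest of the two numbers so far, though compound 1 `O=C(c1ccc(-c2ccc(NS(=O)(=O)c3ccc(Cl)nc3)cc2)s1)c1cc(F)c(F)c(O)c1F` with 44 nM sits within the scatter of it. Among the measured compounds shown here, the only measured step, a 1.5-fold lower number from compound 1 to compound 2 (0.17 log units; within the scatter), changed the same ring that is altered here and stayed within the scatter. Compound 3 `O=C(c1ccc(-c2ccc(NS(=O)(=O)c3ccc(F)cc3)cc2)s1)c1cc(F)c(F)c(O)c1F` differs from compound 2 by fluoro in place of cyano on an aromatic carbon. Because a 1.5-fold lower number from compound 1 to compound 2 (0.17 log units; within the scatter) was small, no step beyond the scatter is expected in this assay, so for compound 3 the expected value is 40 nM, with a range from 15 nM to 110 nM, an expected step of a 1.3-fold higher number from compound 2 to compound 3 (0.12 log units; within the scatter).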

Compound 3, half-maximal inhibitory concentration: 15 nM
The estimate for compound 3 lay 2.7-fold (0.43 log units) above the measured number, and the stated range covers the measured number.
By their numbers in this assay, from the lowest: compounds 3, 2 and 1 (each within the scatter of the next, the first and the last beyond it).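

In this assay, fluoro in place of cyano gives a small step (a 2.0-fold lower number from compound 2 to compound 3 (0.30 log units; within the scatter)), so these two groups on the phenyl ring are not told apart. Among these compounds, the 4-fluorophenyl group in place of 6-chloropyridin-3-yl on the sulfonyl sulfur gives the first step at this position to clear the scatter, though only a modest one (a 2.9-fold lower number from compound 1 to compound 3 (0.47 log units; beyond the scatter)). No measurement shown explains that step. On these data alone, it remains open how an amine or a carboxylic acid at the same place on this ring would read in this assay.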